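Stereoisomers in the K562 Series: Compound 3 to Compound 4

The compounds below may be only part of what the source reports. "The series", "measured", "known", "first", "only" and "open" are said of these compounds alone.

Measured in a functional assay on K562 cells (Homo sapiens) for inhibition, read by sulforhodamine B assay, with a stated time of 48 h; a higher number here means a weaker inhibitor, a lower number a stronger inhibitor:
- compound 1 `CCCC[C@@]12O[C@]34CCCC=C3C(=O)O[C@@]43[C@H](CCC)[C@H]4C=C(C(=O)N1[C@H](C)c1ccccc1)[C@]32CC4`: 21700 nM
- compound 2 `CCCC[C@]12O[C@@]34CCCC=C3C(=O)O[C@]43[C@@H](CCC)[C@@H]4C=C(C(=O)N1[C@H](C)c1ccccc1)[C@@]32CC4`: 5700 nM
- compound 3 `CCCC[C@@]12O[C@]34CCCC=C3C(=O)O[C@@]43[C@H](CCC)[C@@H]4C=C(C(=O)N1[C@@H](C)c1ccccc1)[C@]32CC4`: 13900 nM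

Compound 3 stands level with compound 1 within the scatter, as a 1.6-fold lower number from compound 1 to compound 3 (0.19 log units; within the scatter) shows. It lies clearly on the weaker side of compound 2, with a 2.4-fold higher number from compound 2 to compound 3 (0.39 log units; beyond the scatter).

Compound 4 `CCCC[C@]12O[C@@]34CCCC=C3C(=O)O[C@]43[C@@H](CCC)[C@H]4C=C(C(=O)N1[C@@H](C)c1ccccc1)[C@@]32CC4` has the same atoms and bonds as compound 3 and differs only in configuration as drawn: the two compounds have the same atoms and bonds and differ only in configuration as drawn: 6 of 7 stereo elements differ; a stereocentre at a saturated ring carbon is drawn S in compound 3 and R in compound 4; a stereocentre at a saturated ring carbon is drawn R in compound 3 and S in compound 4; a stereocentre at a saturated ring carbon is drawn R in compound 3 and S in compound 4; a stereocentre at a saturated ring carbon is drawn R in compound 3 and S in compound 4.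

Going by the values given here, the closest precedent is a 3.8-fold lower number from compound 1 to compound 2 (0.58 log units; beyond the scatter), which also changes six of seven stereo elements and leaves the saturated chain carbon as drawn. The step between compounds 2 and 3 also changes six elements, but it includes that chain carbon, so it bears less directly. Among the compounds with values here, only one such pair supports the expectation, so it remains tentative.

In this assay, a modest move toward a lower number is therefore expected. The expected step is a 3.1-fold lower number from compound 3 to compound 4 (0.49 log units; beyond the scatter). For compound 4 the estimated value is 4500 nM, with an expected range of 2000 nM to 10000 nM.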

Compound 4, half-maximal inhibitory concentration: 5200 nM
Compound 4: middle estimate off by 1.2-fold (0.06 log units), on the low side; the measured number falls inside the stated range.
By their numbers in this assay, from the lowest: compounds 4 and 2 (each within the scatter of the next); then compounds 3 and 1 (each within the scatter of the next).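

With a 2.7-fold lower number from compound 3 to compound 4 (0.43 log units; beyond the scatter), the six-element change has a second independent instance, and it runs the same way as a 3.8-fold lower number from compound 1 to compound 2 (0.58 log units; beyond the scatter). The same six elements, in a third pairing, give a 4.2-fold lower number from compound 1 to compound 4 (0.62 log units; beyond the scatter), again beyond the scatter in this assay. Going by these compounds alone, the two-element change at a saturated ring carbon and the saturated chain carbon also gains a second instance, with a 1.1-fold lower number from compound 2 to compound 4 (0.04 log units; within the scatter) sitting within the scatter, as a 1.6-fold lower number from compound 1 to compound 3 (0.19 log units; within the scatter) does; across these four compounds the number follows the six-element set and not those two elements, and no compound goes against this.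

The compounds shown change the six elements only as a set, so which of them carries the step stays open. Going by these compounds, whether the same split would hold with a longer chain or an amine on the shared core also stays open.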